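The source may report more compounds than this note shows. Statements on the series, on what has been measured and on what is new or still open speak of the compounds shown alone.

Measured so far:

Compound 1, `CCCNc1nc(Cl)nc(N[C@@H](C)c2ccccc2)n1`, in an ADME assay on the whole organism for inhibition, with Echinochloa crus-galli var. formosensis as the target, with a stated time of 4 days; a higher number here means a weaker inhibitor, a lower number a stronger inhibitor: 15100 nM
Compound 2, `CC(C)Nc1nc(Cl)nc(N[C@H](C)c2ccccc2)n1`, in this assay: 2000 nM

Of the two compounds measured, compound 1 has the higher number, and the gap to compound 2 is beyond the usual scatter of repeated measurements, so compound 1 is the weaker inhibitor of the pair. The two compounds differ in more than one place at once, so nothing is known here about what any single change does to the number.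

Compound 3, `CCCN(C)c1nc(Cl)nc(N[C@@H](C)c2ccccc2)n1`, has not yet been measured. It is obtained from compound 1 by one change: methyl in place of hydrogen on a nitrogen on an aromatic ring.

Within the data shown here, there is no measured pair in this set that shows what such a methyl on a ring nitrogen does, so the expectation rests on the general observation that a small change of this kind usually moves a number only modestly. Starting from compound 1 and its value 15100 nM, compound 3 is estimated to land at 25000 nM, within a range of 8000 nM to 80000 nM, which means an expected step from a 1.7-fold higher number from compound 1 to compound 3 (0.22 log units; within the scatter) of a size not clearly beyond the scatter, if anything toward a higher number.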

Compound 3, half-maximal inhibitory concentration: 380 nM
Beside the measured number, compound 3's estimate is 66-fold (1.82 log units) above it; measured number outside the range, below it.
By their numbers in this assay, from the lowest: compound 3; then compound 2; then compound 1.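

Putting methyl in place of hydrogen on the nitrogen on the aromatic ring, the change from propylamino to methyl(propyl)amino, gives a 40-fold lower number from compound 1 to compound 3 (1.60 log units; beyond the scatter) in this assay and so makes compound 3 a much stronger inhibitor than compound 1 on the whole organism. Among these compounds, this is the first comparison in the set in which only one place differs, so it is the first direct look at what a single change does to the number. It shows that this nitrogen is a sensitive position, where one added carbon can produce a large step rather than a modest one, though nothing measured here explains why so small a change has so large a result.

One pair cannot say whether the gain belongs to methyl in particular or would also come with an ethyl group on the same nitrogen. It also leaves open whether the same methyl would give a similar step if the propyl chain on that nitrogen were replaced by a longer chain such as butyl.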